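The source may hold more compounds than are shown below. What is called first, only, known or untested is meant among the compounds shown, and "the series" means these compounds.

Compound 2 `O=C(/C=C/c1ccccc1)OC1(C(=O)Nc2ccc([N+](=O)[O-])cc2)CCCCC1` is one of two esters of a shared core that have been tested in a functional assay on HepG2 cells (Homo sapiens) for inhibition, read by MTT assay, with a stated time of 72 h; a lower number here means a stronger inhibitor, a higher number a weaker inhibitor. In this assay compound 2 gives 52.9 nM, the lower of the two numbers; compound 1 `CCOC(=O)c1ccccc1C(=O)OC1(C(=O)Nc2ccc([N+](=O)[O-])cc2)CCCCC1` gives 517 nM, a gap that lies beyond the scatter of repeated measurements.

Compound 3 `CC(=O)Oc1ccccc1C(=O)OC1(C(=O)Nc2ccc([N+](=O)[O-])cc2)CCCCC1` has not yet been measured. It differs from compound 2 in one place: 2-acetoxyphenyl in place of 2-phenylethenyl on a carbonyl carbon. For the measured compounds named here, no directly comparable step between measured compounds exists for this change, so the expectation rests on the two numbers alone. Since the only other ester on this core, compound 1, stands well above compound 2, a move back toward weaker inhibition appears more likely than a further gain, and compound 3 is therefore expected to sit higher than compound 2 by a 4.7-fold higher number from compound 2 to compound 3 (0.67 log units; beyond the scatter). On this basis compound 3 is estimated at 250 nM, with a plausible range from 80 nM to 800 nM.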

Compound 3, half-maximal inhibitory concentration: 17.7 nM
Estimate against measurement, compound 3: 14-fold (1.15 log units) above; the measured number lies below the stated range.
By their numbers in this assay, from the lowest: compound 3; then compound 2; then compound 1.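

In this assay, the step of a 3.0-fold lower number from compound 2 to compound 3 (0.48 log units; beyond the scatter) shows that the 2-phenylethenyl group on this carbonyl carbon can be replaced by an aromatic ring with a gain, so the weaker number of compound 1 does not hold for every substituted ring at this position. The step of a 29-fold lower number from compound 1 to compound 3 (1.47 log units; beyond the scatter) places the difference on a single aromatic carbon, where acetoxy and ethoxycarbonyl give very different numbers on an otherwise identical ester. Nothing given here accounts for either step.

Still open, on these data alone, is how a hydroxy group, an amine or a carboxylic acid on that aromatic carbon would compare with acetoxy. It is also unknown whether a longer chain such as propanoyloxy would keep the number of compound 3.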